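Adding an amine to a cinnamamide-linked trimethoxybenzophenone

This account rests on a few compounds, and the source may have more. Where it says the series, first, only, none or still open, it means among the compounds named here.

Three compounds share one core and differ only in the aryl ring at the far end of the double-bonded chain. Compound 1 `COc1ccc(/C=C/C(=O)Nc2cc(C(=O)c3cc(OC)c(OC)c(OC)c3)cc(OC)c2OC)cc1OC` gives 7800 nM in a functional assay on DU-145 cells (Homo sapiens) for cytotoxicity, read by MTT assay, with a stated time of 72 h; on this read-out lower numbers stand for stronger inhibition and higher numbers for weaker inhibition. Compound 2 `COc1ccc(/C=C/C(=O)Nc2cc(C(=O)c3cc(OC)c(OC)c(OC)c3)cc(OC)c2OC)cc1` gives 10400 nM, and compound 3 `COc1cccc(/C=C/C(=O)Nc2cc(C(=O)c3cc(OC)c(OC)c(OC)c3)cc(OC)c2OC)c1` gives 12500 nM. Removing a methoxy group gave a 1.3-fold higher number from compound 1 to compound 2 (0.12 log units; within the scatter) and a 1.6-fold higher number from compound 1 to compound 3 (0.20 log units; within the scatter), and moving it gave a 1.2-fold higher number from compound 2 to compound 3 (0.08 log units; within the scatter). Compound 3 carries the largest number of the three, yet none of these steps separates it from its neighbours beyond the scatter.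

Compound 4 `COc1ccc(/C=C/C(=O)Nc2cc(C(=O)c3cc(OC)c(OC)c(OC)c3)cc(OC)c2OC)cc1N` is the next step: 3-amino-4-methoxyphenyl in place of 3-methoxyphenyl on a double-bonded chain carbon bound to a double-bonded chain carbon. Among the measured compounds shown here, no measured step covers an added amine, and the three changes seen so far, all within the scatter, give no ground to expect a large shift. The step from compound 3 to compound 4 in this assay is therefore expected to be modest, estimated as a 1.8-fold lower number from compound 3 to compound 4 (0.25 log units; within the scatter). Compound 4 is expected to give about 7000 nM, within a range of 2500 nM to 20000 nM.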

Compound 4, half-maximal inhibitory concentration: 12700 nM
Beside the measured number, compound 4's estimate is 1.8-fold (0.26 log units) below it; measured number inside the range.
By their numbers in this assay, from the lowest: compounds 1, 2, 3 and 4 (each within the scatter of the next).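

Among the compounds shown here, the amino group adds something the earlier compounds did not have: the 3-amino-4-methoxyphenyl group brings a hydrogen-bond donor onto the aryl ring, yet in this assay amino in place of hydrogen on an aromatic carbon gives a 1.2-fold higher number from compound 2 to compound 4 (0.09 log units; within the scatter). Amino in place of methoxy on that carbon gives a 1.6-fold higher number from compound 1 to compound 4 (0.21 log units; within the scatter), and the swap from 3-methoxyphenyl gives a 1.0-fold higher number from compound 3 to compound 4 (0.01 log units; within the scatter), so this aromatic carbon has now carried hydrogen, methoxy and amino with no step beyond the scatter. Nothing shown here explains this insensitivity.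

From the compounds shown here alone, whether a hydroxyl, a carboxylic acid or a longer chain on this aromatic carbon would give a step beyond the scatter remains open. So does whether a dimethylamino group there would behave as the amino group does.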